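This account rests on a few compounds, and the source may have more. Where it says the series, first, only, none or still open, it means among the compounds named here.

Of the compounds shown here, three have been measured in a functional assay on MOLT-4 cells (Homo sapiens) for inhibition; a higher number here means a weaker inhibitor of growth, a lower number a stronger inhibitor of growth. Compound 1, `CC(=O)CC/C=C(\C)CCC1=C(C)CCCC1(C)C`, gives 2080 nM. Compound 3, `C=C1CCCC(C)(C)C1CC[C@@]1(C)CC[C@H]([C@@H](C)C(=O)O)OO1`, gives 2160 nM. Compound 2, `CC1=C(CC/C(C)=C/CC[C@@]2(C)CC[C@@H]([C@H](C)C(=O)O)OO2)C(C)(C)CCC1`, gives 42600 nM, the highest number of the three and therefore the weakest inhibitor of growth among them: its gap to compound 3 and its gap to compound 1 both lie well beyond the usual scatter of this assay.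

The step now followed leads from compound 2 to compound 4, `CC1=C(CC/C(C)=C/CC[C@@]2(C)CC[C@H]([C@H](C)C(=O)O)OO2)C(C)(C)CCC1`. Going by the values given here, the two are built from the same atoms and bonds, and the only change is this: the two compounds have the same atoms and bonds and differ only in configuration as drawn: 1 of 4 stereo elements differ; a stereocentre at a saturated ring carbon is drawn S in compound 2 and R in compound 4. Nothing comparable has been measured as a single step here, so the direction and size of the change have to be guessed. A change of configuration at one centre can leave the number roughly where it is or move it considerably in either direction. Since compound 2 already sits at the top of the range with 42600 nM, and compounds 1 and 3 show that the general scaffold can reach far lower numbers, a move downward seems at least as likely as a move upward. Compound 4 is therefore expected to give about 12000 nM, with a plausible range from 3000 nM to 50000 nM, which would mean an estimated step of a 3.6-fold lower number from compound 2 to compound 4 (0.55 log units; beyond the scatter).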

Compound 4, concentration for 50% growth inhibition: > 5000 nM
Compound 4: only a limit was reported; the forecaster's own chance of this, stated with the estimate: 5%; the middle value lies beyond the limit too.
By their numbers in this assay, from the lowest: compounds 1 and 3 (each within the scatter of the next); then compound 2.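

In this assay compound 4 gives > 5000 nM, which is a limit of the assay and not a number. The step from compound 2 to compound 4 therefore cannot be read. The compounds shown leave open whether drawing this one saturated ring carbon as R instead of S changes growth inhibition at all, and in which direction.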